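Swapping the Amide Substituent on a Pyrazole Scaffold

A few compounds are considered here, and "the series" means these few. Any claim that something is new, unique, unknown or untested is made for them only; others in the source may bear on it.

Measured compounds:
Compound 1, `Cc1cc(C(=O)Nc2cccc(F)c2)nn1Cc1cc(Cl)ccc1OCc1ccccc1`, gives 2.8 in a physicochemical assay for lipophilicity, at pH 7.4; on this read-out lower numbers stand for lower lipophilicity and higher numbers for higher lipophilicity.
Compound 2, `Cc1cc(NC(=O)C2CCOCC2)nn1Cc1cc(Cl)ccc1OCc1ccccc1`, gives > 3.7 in this assay, a limit of the assay rather than a number.

Compound 2 therefore stands at the upper limit of this assay, as described by the limit of > 3.7 in this assay, at which 1 of the 2 values shown sits; only a range is known for it. Going by the values given here, the one measured step that bears on the present question is a number at least 0.90 log units higher from compound 1 to compound 2 (beyond the scatter), an increase that is at least modest and lies beyond the scatter. Compound 3, `Cc1cc(NC(=O)OCc2ccccc2)nn1Cc1cc(Cl)ccc1OCc1ccccc1`, differs from compound 2 by benzyloxy in place of oxan-4-yl on a carbonyl carbon. With compound 2 already at the limit, compound 3 is expected to remain at or beyond that limit, and the step is estimated as a step that the limit leaves unreadable from compound 2 to compound 3. Compound 3 is estimated at 4.4 in this assay, with a range from 3.8 to 5.2, and a further limit rather than a number is expected.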

Compound 3, distribution coefficient: 3.1
Compound 3: the middle estimate sits 1.30 log units above what was measured, and the stated range ends above it.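

Replacing oxan-4-yl with benzyloxy on the carbonyl carbon gives a number at least 0.60 log units lower from compound 2 to compound 3 (beyond the scatter), which shows that in this assay the group at this place can bring the read-out back from the limit seen for compound 2. Replacing (3-fluorophenyl)carbamoyl with (benzyloxycarbonyl)amino gives a number 0.30 log units higher from compound 1 to compound 3 (within the scatter), so this read-out does not separate these two groups on an aromatic carbon. The full size of the first step stays unknown because compound 2 gives only a limit and not a number: the limit of > 3.7 in this assay, at which 1 of the 3 values shown sits.

The compounds shown leave open how the read-out would respond to an amine or a carboxylic acid on the same carbonyl carbon. On these data alone, whether a plain benzyl group there would behave as benzyloxy does also remains open.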